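Methoxy count and a benzyloxy extension on the shared core

This account rests on a few compounds, and the source may have more. Where it says the series, first, only, none or still open, it means among the compounds named here.

The shared core is carried by compound 1 `COc1ccc(-c2nnc(-c3c[nH]c4ccccc34)o2)cc1`, compound 2 `COc1ccc(-c2nnc(-c3c[nH]c4ccccc34)o2)cc1OC` and compound 3 `COc1ccc(-c2nnc(-c3c[nH]c4ccccc34)o2)c(OC)c1OC`, which differ only in how many methoxy groups sit on the pendant aromatic ring. In a functional assay on MDA-MB-231 cells (Homo sapiens) for cytotoxicity, read by MTT assay (on this read-out lower numbers stand for stronger inhibition and higher numbers for weaker inhibition), compound 1 gives only a limit, > 1000000 nM. In this assay compound 2 likewise reaches only a limit, > 1000000 nM. Compound 3 also stops at a limit, > 1000000 nM. The step that the two limits leave unreadable from compound 1 to compound 2 and the step that the two limits leave unreadable from compound 2 to compound 3 stay unreadable, as the limit of > 1000000 nM in this assay, at which 3 of the 3 values shown sit, records. Compound 2 thus stands at the limit, and no number for it is known.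

Compound 4 `COc1cc(-c2nnc(-c3c[nH]c4ccccc34)o2)ccc1OCc1ccccc1` is the next member to be measured. Relative to compound 2 the change is phenyl in place of hydrogen on a saturated chain carbon bound to an oxygen on an aromatic ring. Both measured steps run between values at the limit and give no readable size, so nothing among them tells how this extension will read in this assay. For compound 4 the expected step is an at least 1.2-fold lower number from compound 2 to compound 4 (0.09 log units; that floor lies within the scatter), with a high chance that only a limit is returned again. Compound 4 is therefore estimated at 800000 nM, within 100000 nM to 3000000 nM.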

Compound 4, half-maximal inhibitory concentration: > 1000000 nM
Compound 4: only a limit was reported (the forecaster's own chance of this, stated with the estimate: 70%); middle value at least 1.2-fold (0.09 log units) from the limit.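

Compound 4 gives only a limit, > 1000000 nM, in this assay. No new step can be read between compound 2 and compound 4: the limit of > 1000000 nM in this assay, at which 4 of the 4 values shown sit.

The compounds shown leave open whether methoxy count or the benzyloxy extension changes the read-out on the shared core at all.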